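Fluoro for cyano on the sulfonyl aryl of compound 2

The compounds below may be only part of what the source reports. "The series", "measured", "known", "first", "only" and "open" are said of these compounds alone.

Measured so far:
compound 1, `CCN(CC)c1ccc2cc(C(=O)c3ccc(N4CCN(C(=O)CN5CCN(C(=O)CCl)CC5)CC4)cc3)oc2c1`: > 40000 nM
compound 2, `CCN(CC)c1ccc2cc(C(=O)c3ccc(N4CCN(C(=O)CN5CCN(S(=O)(=O)c6ccc(C#N)cc6)CC5)CC4)cc3)oc2c1`: 36400 nM

Among the measured compounds shown here, in a functional assay on HCT-116 cells (Homo sapiens) for cytotoxicity, read by MTT assay, with a stated time of 48 h (a higher number here means a weaker inhibitor, a lower number a stronger inhibitor), compound 2 gives 36400 nM, the only value in the set that is a number. Compound 1 in this assay reaches only a limit, > 40000 nM. For the measured compounds named here, the single measured step, an at least 1.0-fold lower number from compound 1 to compound 2 (0.04 log units; that floor lies within the scatter), sits within the scatter, with one end resting on (the limit of > 40000 nM in this assay, at which 1 of the 2 values shown sits).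

Compound 3, `CCN(CC)c1ccc2cc(C(=O)c3ccc(N4CCN(C(=O)CN5CCN(S(=O)(=O)c6ccc(F)cc6)CC5)CC4)cc3)oc2c1`, differs from compound 2 by fluoro in place of cyano on an aromatic carbon. Going by the values given here, no measured step touches the sulfonyl aryl, so nothing read so far sets a size for this change. Compound 3 is therefore expected to stay close to compound 2. The expected step is a 1.1-fold higher number from compound 2 to compound 3 (0.04 log units; within the scatter). Compound 3 is estimated at 40000 nM, within 15000 nM to 100000 nM.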

Compound 3, half-maximal inhibitory concentration: > 40000 nM
Compound 3 ended at the assay's limit; the forecaster's own chance of this, stated with the estimate: 50%; the middle value sits exactly at the limit.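

With fluoro in place of cyano, the sulfonyl aryl gives its first reading in this assay, and the floor of this step lies within the scatter (an at least 1.0-fold higher number from compound 2 to compound 3 (0.04 log units; that floor lies within the scatter)). Compound 3 (> 40000 nM) stands at a limit of the assay, not at a number. The step between compound 1 and compound 3 cannot be read, and most of the set stays at one limit: (the limit of > 40000 nM in this assay, at which 2 of the 3 values shown sit).

On these data alone, whether any group on this aryl carries the value clear of the scatter remains open. An amine, a carboxylic acid or a methoxy group there would be untested ground.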